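This account rests on a few compounds, and the source may have more. Where it says the series, first, only, none or still open, it means among the compounds named here.

Measured compounds in a functional assay on HT-29 cells (Homo sapiens) for cytotoxicity, read by MTT assay, with a stated time of 72 h; on this read-out higher numbers stand for weaker inhibition and lower numbers for stronger inhibition:

Compound 1 `COc1ccc(/C=C/C(=O)Nc2cc(C(=O)c3cc(OC)c(OC)c(OC)c3)ccc2OC)cc1`, 5010 nM
Compound 2 `C#CCOc1cccc(/C=C/C(=O)Nc2cc(C(=O)c3cc(OC)c(OC)c(OC)c3)ccc2OC)c1`, 7400 nM

Compound 2 holds the highest of the two numbers in this assay, with compound 1 as its nearest neighbour at a distance that sits within the scatter. Among the measured compounds shown here, the only measured step, a 1.5-fold higher number from compound 1 to compound 2 (0.17 log units; within the scatter), is therefore the sole comparison available, and it says little more than that this change on the double-bonded chain left the read-out essentially where it was.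

Compound 3 `COc1ccc(C(=O)c2cc(OC)c(OC)c(OC)c2)cc1NC(=O)/C=C/c1cccc(OC(F)(F)F)c1` is the next member. It differs from compound 2 by trifluoromethyl in place of propargyl on an oxygen on an aromatic ring. For the measured compounds named here, no measured pair shows this exact change, so the expectation rests on the weak precedent of compound 1 to compound 2, where an exchange at the same part of the molecule stayed within the scatter. The step of a 1.1-fold lower number from compound 2 to compound 3 (0.02 log units; within the scatter) is accordingly expected to be small in this assay, with no clear direction beyond the scatter. Compound 3 is estimated at 7000 nM, within a range from 2500 nM to 20000 nM.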

Compound 3, half-maximal inhibitory concentration: 5200 nM
Compound 3: the middle estimate sits 1.3-fold (0.13 log units) above what was measured; the measured number falls inside the stated range.
By their numbers in this assay, from the lowest: compounds 1, 3 and 2 (each within the scatter of the next).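

In this assay, the exchange of propargyl for trifluoromethyl on the oxygen on the aromatic ring gives a 1.4-fold lower number from compound 2 to compound 3 (0.15 log units; within the scatter), so this second replacement in the same part of the molecule also stays within the scatter. Among the compounds shown here, the step 3-(trifluoromethoxy)phenyl in place of 4-methoxyphenyl gives a 1.0-fold higher number from compound 1 to compound 3 (0.02 log units; within the scatter), which is also within the scatter, so the read-out does not separate 4-methoxyphenyl, 3-(propargyloxy)phenyl and 3-(trifluoromethoxy)phenyl, whereas the earlier pair could speak for only two of these groups. Nothing given here explains why the three numbers lie so close together.

The compounds shown leave open whether any group on this ring can move the number beyond the scatter, for instance an amine, a carboxylic acid, a hydroxyl or a longer chain on the oxygen. They also leave open whether 3-methoxyphenyl or 4-(trifluoromethoxy)phenyl would read the same, which would help separate the identity of the group from its place on the ring.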